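The source may report more compounds than this note shows. Statements on the series, on what has been measured and on what is new or still open speak of the compounds shown alone.

Measured in an ADME assay on MT4 cells (Homo sapiens) for cytotoxicity, read by MTT assay, with a stated time of 96 h; on this read-out lower numbers stand for higher toxicity in this test and higher numbers for lower toxicity in this test:

compound 1 `Cc1ccc(/N=N/N(C)c2ccccc2)cc1` gives 45000 nM
compound 2 `Cc1ccc(/N=N/c2ccc(NCCCN(C)C)cc2)cc1` gives 17000 nM
compound 3 `CN(/N=N/c1ccccc1)c1ccccc1` gives 55000 nM

Compound 3 differs from compound 1 by hydrogen in place of methyl on an aromatic carbon, and the step is a 1.2-fold higher number from compound 1 to compound 3 (0.09 log units; within the scatter). Compound 2 gives the lowest of the three numbers; the difference between its core and the core of compound 1 is not broken down here.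

Compound 4 `CN(C)CCCNc1ccc(/N=N/c2ccccc2)cc1` differs from compound 2 by hydrogen in place of methyl on an aromatic carbon. The place is described in the same words as for the change from compound 1 to compound 3, so this is the same change, made a second time on a different core. Among the compounds with values here, the step from compound 2 to compound 4 in this assay is expected to be a 1.2-fold higher number from compound 2 to compound 4 (0.07 log units; within the scatter), resting on the single measured instance of this change, a 1.2-fold higher number from compound 1 to compound 3 (0.09 log units; within the scatter), which stayed within the scatter. For compound 4 in this assay the estimate is 20000 nM, expected between 10000 nM and 40000 nM.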

Compound 4, half-maximal cytotoxic concentration: 17000 nM
Beside the measured number, compound 4's estimate is 1.2-fold (0.07 log units) above it; low and high end bracket the measured number.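

In this assay, going from 4-methylphenyl to phenyl gives no change at the digits printed from compound 2 to compound 4 (within the scatter), so this change again leaves the number in place on a second core. Within the data shown here, this shows only that removing this methyl makes no difference beyond the scatter on these two cores; with two pairs and no sizeable step on either, it does not show that a larger effect would carry over, nor that the result holds on any other core. The two steps agree within the scatter: the same change on two cores in this assay, a 1.2-fold higher number (0.09 log units; within the scatter) from compound 1 to compound 3 and no change at the digits printed (within the scatter) from compound 2 to compound 4, 1.2-fold (0.09 log units) apart, within the scatter of two such steps

Still open, going by these compounds, is whether a larger replacement at the same place, such as a methoxy group, an amine or a carboxylic acid, would move the number. Also open, on these data alone, is whether a longer chain on the core of compound 2 would change the reading.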